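Swapping fluoro for methyl on a well-tolerated compound

The source may hold more compounds than are shown below. What is called first, only, known or untested is meant among the compounds shown, and "the series" means these compounds.

Values so far in an ADME assay on Vero cells (Chlorocebus sabaeus) for cytotoxicity (a higher number here means that more compound is tolerated, a lower number that less compound is tolerated), for three compounds
Compound 1 `Nc1nc(F)cc2c1ncn2[C@@H]1C=C(CCO)[C@@H](O)[C@H]1O` gives > 100000 nM as a limit
Compound 2 `Nc1ncc(F)c2c1ncn2[C@@H]1C=C(CO)[C@@H](O)[C@H]1O` gives 224000 nM as a number
Compound 3 `Nc1ncc(F)c2c1ncn2[C@@H]1C=C(CCO)[C@@H](O)[C@H]1O` gives > 340000 nM as a limit

Only compound 2 has an actual number in this assay here. The values of compound 1 and compound 3 are limits. That makes compound 2 at 224000 nM the one firm starting point.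

Compound 4 `Cc1cnc(N)c2ncn([C@@H]3C=C(CO)[C@@H](O)[C@H]3O)c12` has not been measured yet. It departs from compound 2 in one place: methyl in place of fluoro on an aromatic carbon and the rest of the structure stays the same.

For the measured compounds named here, the only measured step is an at least 1.5-fold higher number from compound 2 to compound 3 (0.18 log units; that floor lies within the scatter) and it concerns another place, hydroxymethyl in place of hydroxy on a saturated chain carbon. Going by the values given here, no measured step touches the aromatic carbon that changes here, and no compound with this methyl has a value yet. That step is therefore only a weak guide, and no change beyond the usual scatter is expected in this assay in either direction. The estimate amounts to a 1.1-fold lower number from compound 2 to compound 4 (0.05 log units; within the scatter) as an expected change. The estimated value for compound 4 is 200000 nM with an expected range from 70000 nM to 400000 nM in repeated measurements.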

Compound 4, half-maximal cytotoxic concentration: > 362000 nM
Compound 4 gave a limit, no number; the forecaster's own chance of this, stated with the estimate: 50%; at least 1.8-fold (0.25 log units) between middle value and limit.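

This is the only measured change shown on the aromatic carbon para to an amino group, and in this assay compound 4 gives > 362000 nM, which is a limit and not a number. For the compounds shown here, the step reads an at least 1.6-fold higher number from compound 2 to compound 4 (0.20 log units; that floor lies within the scatter), so methyl in place of fluoro at this position gives no sign that less compound is tolerated, although the floor of the step does not by itself show a real gain. The true size of the step cannot be read, because compound 4 stands at a limit of the assay: the limit of > 362000 nM in this assay, at which 1 of the 4 values shown sits.

The compounds shown leave open whether a larger group on this aromatic carbon, such as ethyl, methoxy or a dimethylamino group, would be tolerated as well as methyl, since fluoro and methyl are each a single heavy atom. They also leave open what happens when methyl on this carbon is combined with the longer chain of compound 3, and whether the result seen here in this assay would hold in any other cell type.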